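Cyano to tert-Butyl: What to Expect for Compound 3

The compounds below may be only part of what the source reports. "The series", "measured", "known", "first", "only" and "open" are said of these compounds alone.

Compound 1 `Cc1cccc(Oc2cccc(COc3ccccc3CCC(=O)OCCCOP(=O)(O)OC[C@H](N)C(=O)O)c2)c1`: 21.3%
Compound 2 `N#Cc1ccc(Oc2cccc(COc3ccccc3CCC(=O)OCCCOP(=O)(O)OC[C@H](N)C(=O)O)c2)cc1`: 18.3%

Both compounds were tested in an assay on cells for agonist activity at probable G-protein coupled receptor 34 (Mus musculus), with a stated time of 1 h; a higher number here means a larger maximal response, a lower number a smaller maximal response. Within the data shown here, compound 2 holds the lower of the two numbers, but the only step measured so far, a number 3 percentage points lower from compound 1 to compound 2 (within the scatter), lies within the scatter, so the two compounds cannot be told apart on this read-out.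

Compound 3 `CC(C)(C)c1ccc(Oc2cccc(COc3ccccc3CCC(=O)OCCCOP(=O)(O)OC[C@H](N)C(=O)O)c2)cc1` has not yet been measured. It differs from compound 2 by tert-butyl in place of cyano on an aromatic carbon. Among the measured compounds shown here, no measured step covers this exchange: the single step in the set concerns a different pair of groups and was small anyway. On these data alone, nothing in the data therefore points to a change beyond the scatter, and a step of a number 1.7 percentage points higher from compound 2 to compound 3 (within the scatter) is expected, with wide uncertainty since the exchange is untested. Compound 3 is estimated to give 20% in this assay, within a range of 8% to 34%.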

Compound 3, largest response reached (Emax), in percent of the reference or control that the assay uses: 16.9%
Beside the measured number, compound 3's estimate is 3.1 percentage points above it; low and high end bracket the measured number.
By their numbers in this assay, from the lowest: compounds 3, 2 and 1 (each within the scatter of the next).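

At this aromatic carbon, cyano (2 heavy atoms, 1 hydrogen-bond acceptor) gives way to tert-butyl (4 heavy atoms, 0 hydrogen-bond acceptors), and this assay records a number 1.4 percentage points lower from compound 2 to compound 3 (within the scatter), so this exchange produces no readable change in maximal response. The comparison with the 3-methylphenyl group gives a number 4.4 percentage points lower from compound 1 to compound 3 (within the scatter), which means that all three aryl groups now tested on this oxygen remain indistinguishable on this read-out. No measurement is available that could explain this result.

On these data alone, whether a different kind of group at this carbon, such as an amine or a carboxylic acid, would move the response beyond the scatter remains open. The effect of a longer chain elsewhere on the shared core is equally unknown.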